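This account rests on a few compounds, and the source may have more. Where it says the series, first, only, none or still open, it means among the compounds named here.

In an ADME assay on microsomes from liver (Rattus norvegicus) for metabolic stability, read by mass spectrometry, using NADPH, with a stated time of 10 min (on this read-out lower numbers stand for a less stable compound and higher numbers for a more stable compound), compound 1 (`CCCCc1[nH]c(=O)c(-c2nnc(Cc3cccc(Cl)c3)o2)c(O)c1-c1c(OC)cccc1OC`) gives 38% as the lowest of three numbers. Compound 2 (`CCCCc1[nH]c(=O)c(-c2nnc(Cc3ccccc3)o2)c(O)c1-c1c(OC)cccc1OC`) gives 53% and compound 3 (`COCCc1[nH]c(=O)c(-c2nnc(Cc3ccc(Cl)cc3)o2)c(O)c1-c1c(OC)cccc1OC`) gives 73% in the same read-out. Compound 4 (`CCCCc1[nH]c(=O)c(-c2nnc(Cc3ccc(Cl)cc3)o2)c(O)c1-c1c(OC)cccc1OC`) has not yet been measured. Its change from compound 1 is 4-chlorophenyl in place of 3-chlorophenyl on a saturated chain carbon bound to an aromatic carbon and leaves the atoms the same.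

Within the data shown here, only one measured step bears directly on this change. The step of a number 15 percentage points higher from compound 1 to compound 2 (beyond the scatter) is modest and beyond the scatter, but it removes the chloro altogether, whereas compound 4 keeps it. Among the measured compounds shown here, no measured pair moves a chloro from one place to another, so the size of such a move remains unknown. Compound 3 also carries the 4-chlorophenyl group, but it differs from compound 1 in its other chain as well and offers no clean comparison.

With the chloro retained, compound 4 is expected to lie closer to compound 1 at 38% than to compound 2 at 53% in this read-out. The estimate is a number 5 percentage points higher from compound 1 to compound 4 (within the scatter) as an expected small upward move that stays inside the scatter. For compound 4 the expected value is 43% with an estimated range from 28% to 58% in this read-out.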

Compound 4, percent of the compound remaining: 22%
For compound 4 the middle estimate is 21 percentage points above the measured one; the whole stated range lies above it.
By their numbers in this assay, from the lowest: compound 4; then compound 1; then compound 2; then compound 3.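

In this assay, the place of the chloro matters even though the atoms stay the same: going from 3-chlorobenzyl to 4-chlorobenzyl gives a number 16 percentage points lower from compound 1 to compound 4 (beyond the scatter), and restoring chloro on the unsubstituted phenyl gives a number 31 percentage points lower from compound 2 to compound 4 (beyond the scatter), so among these three compounds the one without chloro has the highest number, with neither chloro isomer reaching it. With the 4-chlorophenyl group held constant, a clean comparison of the other chain is now available: ethyl in place of methoxy on a saturated chain carbon, two bonds along the chain from an aromatic carbon, gives a number 51 percentage points lower from compound 3 to compound 4 (beyond the scatter), the largest step in this small set. Nothing at hand explains either the chloro shift or the chain shift.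

Among these compounds, whether the methoxy-bearing chain would give a similar rise with the 3-chlorophenyl or the unsubstituted phenyl group remains open, as compound 3 is the only example with that chain. On these data alone, it is also open how a fluoro, a nitrile or an amine in place of the chloro would compare in this read-out.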